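Indole in place of furan on a shared carboxamide

The source may report more compounds than this note shows. Statements on the series, on what has been measured and on what is new or still open speak of the compounds shown alone.

Measured compounds:
compound 1, `CC(C)(C)OC(=O)n1cc(-c2cccc(NC(=O)c3cc4ccccc4[nH]3)c2)nc1N`, > 30000 nM
compound 2, `CNc1nc(-c2cccc(NC(=O)c3ccco3)c2)cn1C(=O)OC(C)(C)C`, > 30000 nM

Compound 2 was tested in an assay on isolated protein for inhibition of sodium channel protein type 4 subunit alpha (Homo sapiens), read by electrophysiology, with a stated time of 4 min; a lower number here means a stronger inhibitor, a higher number a weaker inhibitor. The value reported for compound 2 in this assay, > 30000 nM, is a limit of the assay and not a number. For compound 1 the value in this assay, > 30000 nM, is likewise a limit. Among the measured compounds shown here, both results therefore rest on (the limit of > 30000 nM in this assay, at which 2 of the 2 values shown sit), so no step between measured compounds can be drawn, and compound 2 cannot be placed relative to compound 1 beyond the fact that the two share this limit.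

Compound 3, `CNc1nc(-c2cccc(NC(=O)c3cc4ccccc4[nH]3)c2)cn1C(=O)OC(C)(C)C`, is not yet measured. It differs from compound 2 in one place: 1H-indol-2-yl in place of furan-2-yl on a carbonyl carbon. Compound 1 carries the same 1H-indol-2-yl group on its carbonyl carbon and gives only the limit > 30000 nM in this assay, so compound 3 is expected to remain at or near that limit as well. The step from compound 2 to compound 3 is estimated as a number no higher from compound 2 to compound 3 (the limit leaves the size open), which is not expected to move beyond the scatter in any direction. For compound 3 in this assay the estimate is 30000 nM, with a range from 10000 nM to 100000 nM.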

Compound 3, half-maximal inhibitory concentration: > 30000 nM
Compound 3: a limit, no number (the forecaster's own chance of this, stated with the estimate: 80%); the middle value lies on the limit itself.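

In this assay compound 3 gives > 30000 nM, which is a limit of the assay and not a number. No step from compound 1 or compound 2 to compound 3 can be read: the limit of > 30000 nM in this assay, at which 3 of the 3 values shown sit.

The compounds shown leave open whether 1H-indol-2-yl in place of furan-2-yl, or methyl in place of hydrogen on the nitrogen, changes inhibition at all.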